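This account rests on a few compounds, and the source may have more. Where it says the series, first, only, none or still open, it means among the compounds named here.

Compound 1 `CNC1=C([N+](=O)[O-])C(c2ccc(N3CCN(c4ccnc5cc(Cl)ccc45)CC3)cc2)c2ccccc2O1` is the starting point of this comparison. In an ADME assay on Vero cells (Chlorocebus sabaeus) for cytotoxicity, read by MTT assay, with a stated time of 72 h (on this read-out lower numbers stand for higher toxicity in this test and higher numbers for lower toxicity in this test), compound 1 gives only a limit of the assay, > 200000 nM, so no exact number is known for it. Two close relatives carry a single extra group on one ring of the shared core. Compound 2 `CNC1=C([N+](=O)[O-])C(c2ccc(N3CCN(c4ccnc5cc(Cl)ccc45)CC3)cc2)c2cc(Cl)ccc2O1` gives 74500 nM in this assay, and compound 3 `CNC1=C([N+](=O)[O-])C(c2ccc(N3CCN(c4ccnc5cc(Cl)ccc45)CC3)cc2)c2cc(OC)ccc2O1` gives 81900 nM. These amount to an at least 2.6-fold lower number from compound 1 to compound 2 (0.42 log units; beyond the scatter) and an at least 2.4-fold lower number from compound 1 to compound 3 (0.38 log units; beyond the scatter), two additions to that ring each pushing the number downward by a comparable amount, while between the two substituted compounds there is a 1.1-fold higher number from compound 2 to compound 3 (0.04 log units; within the scatter). The unmeasured compound 4 `CCOc1cccc2c1OC(NC)=C([N+](=O)[O-])C2c1ccc(N2CCN(c3ccnc4cc(Cl)ccc34)CC2)cc1` differs from compound 1 by ethoxy in place of hydrogen on an aromatic carbon. The two measured steps bear on this change in that they also add a small group to the same aromatic ring of the core, though placed differently on it, so a step of similar size and direction is expected, namely an at least 2.2-fold lower number from compound 1 to compound 4 (0.34 log units; beyond the scatter). Because compound 1 sits at the limit of > 200000 nM in this assay, at which 1 of the 3 values shown sits, the true size of that step is itself uncertain. Compound 4 is therefore expected to give about 90000 nM in this assay, with a plausible range from 40000 nM to 200000 nM.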

Compound 4, half-maximal cytotoxic concentration: 40400 nM
Beside the measured number, compound 4's estimate is 2.2-fold (0.35 log units) above it; the measured number falls inside the stated range.
By their numbers in this assay, from the lowest: compounds 4, 2 and 3 (each within the scatter of the next, the first and the last beyond it). At a limit, above all of these: compound 1.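

Ethoxy on the aromatic carbon ortho to a fused ring brings an at least 4.9-fold lower number from compound 1 to compound 4 (0.69 log units; beyond the scatter), so this place on the ring also responds to an added group, and the lower number stands for higher toxicity in this assay. With this third step, all three additions to this ring of the shared core shown here, chloro, methoxy and ethoxy, lower the number, and none of the compounds goes against that pattern, although the new group sits at a different place from the earlier two. The true size of the new step stays unknown, and it can only be read as a minimum, because compound 1 gives no exact number but only a limit of the assay: the limit of > 200000 nM in this assay, at which 1 of the 4 values shown sits.

The compounds shown leave open whether the lower number follows the ethoxy group itself or this place on the ring, as the chloro of compound 2 and the methoxy of compound 3 sit elsewhere on it. Also open, on these data alone, is how a chloro or methoxy group, a longer chain such as butoxy, an amine or a carboxylic acid on this same carbon would read in this assay.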